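Swapping a naphthalene arm for a quinazoline arm

The source may hold more compounds than are shown below. What is called first, only, known or untested is meant among the compounds shown, and "the series" means these compounds.

Measured so far:
compound 1 `Cc1cc(Nc2ccn(Cc3cccc4ccccc34)n2)n2nc(SCc3ccc(Br)cc3)nc2n1` gives 4310 nM
compound 2 `Cc1ccc(CSc2nc3nc(C)cc(Nc4cc(-c5ccccc5)[nH]n4)n3n2)cc1` gives 7290 nM
compound 3 `Cc1cc(Nc2cc(-c3ccccc3)[nH]n2)n2nc(SCc3ccc(Cl)cc3)nc2n1` gives 8260 nM

All three numbers come from a functional assay on MCF7 cells (Homo sapiens) for inhibition, read by MTT assay, with a stated time of 72 h; on this read-out lower numbers stand for stronger inhibition and higher numbers for weaker inhibition. Compound 1 stands within the usual scatter of both neighbours: compound 2 returns a number that is only modestly higher, and compound 3 a number that is likewise close, so no order among the three can be claimed. Among the compounds with values here, the only step between compounds that differ in a single place, a 1.1-fold higher number from compound 2 to compound 3 (0.05 log units; within the scatter), stays within the scatter as well.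

Compound 4 `Cc1cc(Nc2ccn(Cc3nc(C)c4ccccc4n3)n2)n2nc(SCc3ccc(Br)cc3)nc2n1` has not yet been measured. It differs from compound 1 in one place: 4-methylquinazolin-2-yl in place of naphthalen-1-yl on a saturated chain carbon bound to an aromatic nitrogen. The measured step from compound 2 to compound 3 concerns a chloro in place of methyl on an aromatic carbon, a different part of the shared core, so it offers no direct guide to a change on the saturated chain carbon bound to an aromatic nitrogen. Within the data shown here, with no step of this kind on record, no shift beyond the scatter is expected, and compound 4 is estimated at 4500 nM, between 2000 nM and 10000 nM. This estimate means an expected step of a 1.0-fold higher number from compound 1 to compound 4 (0.02 log units; within the scatter) in this assay.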

Compound 4, half-maximal inhibitory concentration: 1430 nM
Compound 4: the middle estimate sits 3.1-fold (0.50 log units) above what was measured; measured number below the stated range.
By their numbers in this assay, from the lowest: compound 4; then compounds 1, 2 and 3 (each within the scatter of the next).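

In this assay, within the data shown here, the swap of naphthalen-1-yl for 4-methylquinazolin-2-yl on a saturated chain carbon bound to an aromatic nitrogen shows a 3.0-fold lower number from compound 1 to compound 4 (0.48 log units; beyond the scatter) and is the only step in this set that lies beyond the scatter, so this position is one where a change can move the number. The earlier step, chloro in place of methyl on an aromatic carbon, sits elsewhere on the molecule and stayed within the scatter, so it gave no such sign. The entering group carries 2 hydrogen-bond acceptors where the leaving group has 0, but this is only a counted difference, and no measurement here ties the step to it or to anything else.

The swap brings in ring nitrogens and a methyl group at the same time, so the compounds shown cannot say which of the two goes with the step; plain quinazolin-2-yl without the methyl would separate them. From the compounds shown here alone, whether an amine or a carboxylic acid on this arm would shift the number further also stays open.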